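Phenyl for thiophen-2-yl on the amide carbonyl

This account rests on a few compounds, and the source may have more. Where it says the series, first, only, none or still open, it means among the compounds named here.

Of the compounds shown here, two have numbers so far. Compound 1 `CCC(=O)N1CCc2cc(CNC(=O)c3ccccc3)ccc21` carries a propanoyl group on the ring nitrogen and a benzamide; in an assay on HEK293 cells for inhibition of Indoleamine 2,3-dioxygenase 1 (Homo sapiens), tested at 10 uM (on this read-out lower numbers stand for less inhibition and higher numbers for more inhibition at the one concentration tested (going by the name of the read-out)), compound 1 gives 87%. Compound 2 `CC(C)C(=O)N1CCc2cc(CNC(=O)c3cccs3)ccc21` carries an isobutyryl group and a thiophene-2-carboxamide; in this assay compound 2 gives 100%, the highest of the two numbers, and its gap to compound 1 lies beyond the scatter.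

Compound 3 `CC(C)C(=O)N1CCc2cc(CNC(=O)c3ccccc3)ccc21` has not yet been measured. It keeps the isobutyryl group of compound 2 and changes only the amide part: phenyl in place of thiophen-2-yl on a carbonyl carbon. Among the compounds with values here, no measured pair shows this exact change, so its effect cannot be read from the series. Compound 1, with the same benzamide but a different acyl group, sits lower than compound 2 in this assay, which points to a small decrease rather than a gain.

For compound 3 in this assay a step of a number 8 percentage points lower from compound 2 to compound 3 (within the scatter) is expected, a modest loss that may stay within the scatter. Compound 3 is estimated at 92%, with a range from 80% to 100%.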

Compound 3, a percentage reported as inhibition, at one concentration (the size of the read-out at that concentration, not a potency): 100%
Beside the measured number, compound 3's estimate is 8 percentage points below it, within the range that was stated.
By their numbers in this assay, from the lowest: compound 1; then compounds 2 and 3 (each within the scatter of the next).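

In this assay, phenyl in place of thiophen-2-yl on a carbonyl carbon gives no change at the digits printed from compound 2 to compound 3 (within the scatter), so with the isobutyryl group held constant this read-out does not separate the two rings. Compound 1 and compound 2 differ in two places, whereas compound 3 differs from compound 1 only in the acyl group: methyl in place of hydrogen on a saturated chain carbon bound to a carbonyl carbon and a saturated chain carbon gives a number 13 percentage points higher from compound 1 to compound 3 (beyond the scatter), and this is the only one of the two new steps that lies beyond the scatter. Nothing at hand offers an explanation for either step.

With a single concentration and compound 3 at 100%, any potency difference between compound 2 and compound 3 remains unresolved, as this read-out is not a potency. Also open, on these data alone, is how the read-out responds to a longer acyl chain in place of isobutyryl, or to an amine or a carboxylic acid on the benzoyl ring.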